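The source may report more compounds than this note shows. Statements on the series, on what has been measured and on what is new or still open speak of the compounds shown alone.

In a functional assay on MCF7 cells (Homo sapiens) for inhibition, read by MTT assay, with a stated time of 72 h (a higher number here means a weaker inhibitor, a lower number a stronger inhibitor), compound 1 (`COc1cc(OC)c(OC)cc1/C=C/C(=O)c1ccc(Cl)cc1`) gives 29500 nM and compound 2 (`COc1cc(OC)c(OC)cc1/C=C/C(=O)c1ccc(F)cc1`) gives 30000 nM, two values within the scatter of each other. Compound 3 (`COc1cc(OC)c(OC)cc1/C=C/C(=O)c1ccc(O)cc1`) has hydroxy in place of fluoro on an aromatic carbon, para to a large group: hydroxy in place of fluoro on an aromatic carbon. Among the measured compounds shown here, the only measured step, a 1.0-fold higher number from compound 1 to compound 2 (0.01 log units; within the scatter), exchanges fluoro for chloro and lies within the scatter, but no hydroxy compound has yet been measured, so it is only weak guidance. The expected change is no larger than the scatter, an estimated 1.2-fold lower number from compound 2 to compound 3 (0.08 log units; within the scatter). For compound 3 the estimated value is 25000 nM, with an expected range of 8000 nM to 60000 nM.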

Compound 3, half-maximal inhibitory concentration: 182000 nM
Estimate against measurement, compound 3: 7.3-fold (0.86 log units) below; the whole stated range lies below it.
By their numbers in this assay, from the lowest: compounds 1 and 2 (each within the scatter of the next); then compound 3.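

Chloro and fluoro could not be told apart at this position, para to a large group, but hydroxy can be told from both in this assay, with a 6.1-fold higher number from compound 2 to compound 3 (0.78 log units; beyond the scatter) and a 6.2-fold higher number from compound 1 to compound 3 (0.79 log units; beyond the scatter) in this set. The position is therefore not indifferent to the group it carries, and among these compounds the weakest inhibitor is compound 3. Nothing measured here explains this change.

Going by these compounds, whether the loss is particular to hydroxy or would follow from any group other than a halogen stays open. The compounds shown include no methoxy, amine or methyl group at this position to decide it.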